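Swapping the aryl group on the shared core of compound 1

The source may hold more compounds than are shown below. What is called first, only, known or untested is meant among the compounds shown, and "the series" means these compounds.

Compound 1 `COc1cc(N2C(=O)C(O)C2c2ccc(SC)cc2)cc(OC)c1OC` is the reference point of this small set. In a functional assay on HL-60 cells (Homo sapiens) for inhibition, read by resazurin assay, with a stated time of 72 h (on this read-out higher numbers stand for weaker inhibition and lower numbers for stronger inhibition), compound 1 gives 15 nM, the lowest of the three numbers. Compound 3 `C=CC1C(=O)N(c2cc(OC)c(OC)c(OC)c2)C1c1ccc(SC)cc1` gives 61 nM in this assay, and the step from it is a 4.1-fold higher number from compound 1 to compound 3 (0.61 log units; beyond the scatter), a change of vinyl in place of hydroxy on a saturated ring carbon. Compound 2 `CCSc1ccc(C2CC(=O)N2c2cc(OC)c(OC)c(OC)c2)cc1` gives 204 nM in this assay; it differs from compound 1 in more than one place, so only the two values themselves can be compared.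

Compound 4 `COc1ccc(C2C(O)C(=O)N2c2cc(OC)c(OC)c(OC)c2)cc1O` has not yet been measured. It differs from compound 1 as follows: 3-hydroxy-4-methoxyphenyl in place of 4-(methylsulfanyl)phenyl on a saturated ring carbon. Going by the values given here, none of the measured steps touches the aryl group on that saturated ring carbon, so no direct precedent exists for this change; the one measured step concerns a different position and was modest. The step from compound 1 to compound 4 in this assay is therefore expected to be small, a 1.3-fold lower number from compound 1 to compound 4 (0.10 log units; within the scatter). Compound 4 is estimated at 12 nM, within a range from 3 nM to 50 nM.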

Compound 4, half-maximal inhibitory concentration: 5 nM
Estimate against measurement, compound 4: 2.4-fold (0.38 log units) above, and the stated range covers the measured number.
By their numbers in this assay, from the lowest: compound 4; then compound 1; then compound 3; then compound 2.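

In this assay, the step of a 3.0-fold lower number from compound 1 to compound 4 (0.48 log units; beyond the scatter) is the only one shown at the aryl position, on the saturated ring carbon next to the ring nitrogen. It runs toward stronger inhibition, whereas the step at the ring atom bearing the hydroxy group, a 4.1-fold higher number from compound 1 to compound 3 (0.61 log units; beyond the scatter), runs toward weaker inhibition. So the 4-(methylsulfanyl)phenyl group is not required for the low number of compound 1, and a 3-hydroxy-4-methoxyphenyl group, which carries a hydrogen-bond donor, can replace it; nothing measured here accounts for the gain.

As far as these compounds go, compound 4 changes the sulfur-bearing group for both a hydroxy and a methoxy group at once, so the share of each in the step stays open. Also open, from the compounds shown here alone, is whether an amine in place of that hydroxy, or this aryl group combined with vinyl on the ring, would keep the number this low.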